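A Longer Side Chain on a Shared Core

The source may hold more compounds than are shown below. What is called first, only, known or untested is meant among the compounds shown, and "the series" means these compounds.

Compound 1 `CCC(C)(O)CC(=O)O[C@H](CC=C(C)C)C1=CC(=O)c2c(O)ccc(O)c2C1=O` was tested in a functional assay on DU-145 cells (Homo sapiens) for cytotoxicity, read by MTT assay (a higher number here means a weaker inhibitor, a lower number a stronger inhibitor), where compound 1 gives 16000 nM. Two relatives were measured in this assay as well: compound 2 `CC(C)=CC[C@@H](OC[C@@H](C)O)C1=CC(=O)c2c(O)ccc(O)c2C1=O` gives 14300 nM, and compound 3 `CC[C@](C)(O)CC(=O)O[C@H](CC=C(C)C)C1=CC(=O)c2c(O)ccc(O)c2C1=O` gives 20500 nM. Compound 1 stands with both inside the usual scatter, since the step of a 1.1-fold lower number from compound 1 to compound 2 (0.05 log units; within the scatter) and the step of a 1.3-fold higher number from compound 1 to compound 3 (0.11 log units; within the scatter) are each small; the pair 1 and 3 differs only in the fact that one of compounds 1 and 3 is drawn with a defined configuration and the other without, at the place where they differ. Compound 4 `CCCC(C)(O)CC(=O)O[C@H](CC=C(C)C)C1=CC(=O)c2c(O)ccc(O)c2C1=O` differs from compound 1 by methyl in place of hydrogen on a saturated chain carbon, three bonds along the chain from an oxygen on a saturated carbon. Within the data shown here, no measured step touches this part of the chain, and every measured step was small, so no change beyond the scatter is expected in this assay. Compound 4 is therefore estimated at 17000 nM, between 8000 nM and 36000 nM, an expected step of a 1.1-fold higher number from compound 1 to compound 4 (0.03 log units; within the scatter).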

Compound 4, half-maximal inhibitory concentration: 75000 nM
Compound 4: middle estimate off by 4.4-fold (0.64 log units), on the low side, and the stated range ends below it.
By their numbers in this assay, from the lowest: compounds 2, 1 and 3 (each within the scatter of the next); then compound 4.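

Among these compounds, this end of the side chain turns out to matter: one added methyl, turning 1-hydroxy-1-methylpropyl into 1-hydroxy-1-methylbutyl, gives a 4.7-fold higher number from compound 1 to compound 4 (0.67 log units; beyond the scatter) in this assay, the first step in this set beyond the scatter. The comparisons with the other two relatives agree, with a 3.7-fold higher number from compound 3 to compound 4 (0.56 log units; beyond the scatter) and a 5.2-fold higher number from compound 2 to compound 4 (0.72 log units; beyond the scatter), so compound 4 is the weakest of the four. From the compounds shown here alone, whether a still longer chain, such as 1-hydroxy-1-methylpentyl, or an amine at this chain end would raise the number further stays open. Nothing shown here accounts for the size of this step.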